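Aryl swap on the ring amine nitrogen

The compounds below may be only part of what the source reports. "The series", "measured", "known", "first", "only" and "open" are said of these compounds alone.

Going by the values given here, compound 1 `Nc1scc(CN2CCN(c3ccc(Cl)cc3F)CC2)c1C(=O)c1ccc(Cl)cc1` holds the lowest of the two numbers so far: in a functional assay on CHO cells with adenosine receptor A1 (Homo sapiens) as the target, read by cAMP accumulation and immunoassay, with a stated time of 6 min, tested at 0.01 uM (a higher number here means a weaker effect of the compound at the concentration tested, a lower number a stronger effect), compound 1 gives -9.2%. Compound 2 `Nc1scc(CN2CCN(C3CCCCCC3)CC2)c1C(=O)c1ccc(Cl)cc1` gives 2.9% in this assay, and the step of a number 12.1 percentage points higher from compound 1 to compound 2 (beyond the scatter) is the only measured one. Compound 3 `Nc1scc(CN2CCN(c3c(F)cc(F)cc3F)CC2)c1C(=O)c1ccc(Cl)cc1` differs from compound 1 by 2,4,6-trifluorophenyl in place of 4-chloro-2-fluorophenyl on an amine nitrogen in a ring. The measured step exchanges an aryl group for cycloheptyl, so it does not bear directly on an aryl-for-aryl change, and no step of that kind is shown. A step within the scatter is therefore expected in this assay, with a number 4.2 percentage points higher from compound 1 to compound 3 (within the scatter) as the estimated size. Compound 3 is estimated at -5%, within -20% to 10%.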

Compound 3, a percentage reported as activity, at one concentration (the size of the read-out at that concentration, not a potency): 4.2%
Compound 3: the middle estimate sits 9.2 percentage points below what was measured, and the stated range covers the measured number.
By their numbers in this assay, from the lowest: compound 1; then compounds 2 and 3 (each within the scatter of the next).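

Keeping an aryl group on this amine nitrogen does not keep the number of compound 1 in this assay: the exchange of one halogenated phenyl for another gives a number 13.4 percentage points higher from compound 1 to compound 3 (beyond the scatter) and is a step of its own. Against the cycloheptyl of compound 2, the 2,4,6-trifluorophenyl gives a number 1.3 percentage points higher from compound 2 to compound 3 (within the scatter), so an aromatic ring alone does not set compound 3 apart. No measured evidence accounts for either step.

Still open, from the compounds shown here alone, is which halogen change within the phenyl ring carries the step from compound 1. Also open, going by these compounds, is how a methoxy group, a nitrile or a carboxylic acid on that phenyl ring would read.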